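The compounds below may be only part of what the source reports. "The series", "measured", "known", "first", "only" and "open" are said of these compounds alone.

Compound 1 (`CCOC(=O)[C@@H]1CCCN(S(=O)(=O)c2ccc(S(=O)(=O)N3CCOCC3)cc2)C1`) is the starting point. In a functional assay on MIA PaCa-2 cells (Homo sapiens) for inhibition, read by MTT assay, with a stated time of 3 days (a lower number here means a stronger inhibitor, a higher number a weaker inhibitor), compound 1 gives 4100 nM, the higher of the two plain numbers at hand. Its nearest neighbour, compound 2 (`CCN(CC)S(=O)(=O)c1ccc(S(=O)(=O)N2CCC[C@@H](C(=O)N3CCN(c4nc(C(F)(F)F)no4)CC3)C2)cc1`), gives 60 nM, a gap well beyond the usual scatter of this kind of measurement. Compound 3 (`CCOC(=O)N1CCC[C@@H](S(=O)(=O)c2ccc(S(=O)(=O)N(CC)CC)cc2)C1`) gives > 10000 nM, which is a limit of the assay rather than a number, (the limit of > 10000 nM in this assay, at which 1 of the 3 values shown sits). Compound 4 (`CCOC(=O)[C@@H]1CCCN(S(=O)(=O)c2ccc(C(=O)N(CC)CC)cc2)C1`) differs from compound 1 in a single place: diethylcarbamoyl in place of (morpholin-4-yl)sulfonyl on an aromatic carbon. Going by the values given here, no measured pair shows exactly this exchange, and compounds 2 and 3 differ from compound 1 in more than this one place, so nothing here fixes the size of the step. The expectation is a modest change, if any, with no clear direction. Compound 4 is therefore estimated at 5000 nM, with a range from 1500 nM to 20000 nM. That estimate means an expected step of a 1.2-fold higher number from compound 1 to compound 4 (0.09 log units; within the scatter), which would lie within the scatter of repeated measurements.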

Compound 4, half-maximal inhibitory concentration: 100 nM
Estimate against measurement, compound 4: 50-fold (1.70 log units) above; measured number outside the range, below it.
By their numbers in this assay, from the lowest: compounds 2 and 4 (each within the scatter of the next); then compound 1. At a limit, above all of these: compound 3.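

Going by these compounds alone, replacing (morpholin-4-yl)sulfonyl with diethylcarbamoyl is the first single-place change in this set, and in this assay it gives a 41-fold lower number from compound 1 to compound 4 (1.61 log units; beyond the scatter), a large step. The position on the aromatic carbon, para to a large group, therefore matters: with the rest of the core of compound 1 unchanged, this one group makes a large difference to the read-out. Nothing measured here accounts for the size of this step.

A morpholin-4-ylcarbonyl group or a diethylsulfamoyl group at this place on the same core would help separate the part played by the carbonyl from that of the two ethyl groups. A shorter amide such as dimethylcarbamoyl, or a carboxylic acid, would show how much change this position can accept.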